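From Butyl to Methyl on the Shared Core

The source may hold more compounds than are shown below. What is called first, only, known or untested is meant among the compounds shown, and "the series" means these compounds.

Of the compounds shown here, two so far have numbers in an ADME assay on MT4 cells (Homo sapiens) for cytotoxicity, read by MTT assay (on this read-out lower numbers stand for higher toxicity in this test and higher numbers for lower toxicity in this test), and the two differ in more than one place. Compound 1 (`CCCCC1C(=O)N(O)C(=O)c2ccccc21`) gives 25400 nM as the lower of the two numbers, which marks it as the more toxic in this test. Compound 2 (`O=c1c2ccccc2c(Cc2ccccc2)c(O)n1O`) gives 88000 nM and stands higher by a gap beyond the usual scatter. Compound 3 (`CC1C(=O)N(O)C(=O)c2ccccc21`) keeps the core of compound 1 and differs from it by one change (hydrogen in place of propyl on a saturated chain carbon bound to a saturated ring carbon). In words, hydrogen takes the place of propyl on a saturated chain carbon bound to a saturated ring carbon, which also reads as butyl to methyl. Among the measured compounds shown here, no measured step of this kind exists, so the expectation in this assay is a moderate upward step towards lower toxicity, possibly not far beyond the scatter. For the measured compounds named here, the only higher number available is that of compound 2 at 88000 nM and it serves as a rough guide to the upper side. The expected step (a 2.4-fold higher number from compound 1 to compound 3 (0.37 log units; beyond the scatter)) is therefore modest. For compound 3 the estimate is 60000 nM with an expected range from 25000 nM to 140000 nM in this test.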

Compound 3, half-maximal cytotoxic concentration: 250000 nM
The estimate for compound 3 lay 4.2-fold (0.62 log units) below the measured number; the measured number lies above the stated range.
By their numbers in this assay, from the lowest: compound 1; then compound 2; then compound 3.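

In this assay, among the compounds shown here, the change from butyl to methyl on the shared core gives a 9.8-fold higher number from compound 1 to compound 3 (0.99 log units; beyond the scatter) and provides the first measured step at this position, on a saturated chain carbon bound to a saturated ring carbon. It shows that the loss of propyl, a group of 3 heavy atoms with no ring, no hydrogen-bond donors or acceptors and no net charge, is enough to move the number well beyond the scatter towards lower toxicity in this test, so the chain at this place clearly matters to the read-out. This is one pair and fixes a direction only for butyl against methyl, and nothing measured here accounts for why the step is so large.

The compounds shown leave open how the number behaves between and beyond these two chains, such as with ethyl or with a chain longer than butyl at this place. They also leave open whether a phenyl ring, an amine or a carboxylic acid carried at the same place on the shared core would move the number in the same direction as methyl or the opposite way.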